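Working notes: from compound 1 to compound 4

The source may report more compounds than this note shows. Statements on the series, on what has been measured and on what is new or still open speak of the compounds shown alone.

Of the compounds shown here, three have numbers so far in a functional assay on the whole organism (strain Kunming) with Mus musculus as the target, with a stated time of 0.5 h (a lower number here means that less compound is needed, a higher number that more compound is needed for the effect), for this series. Compound 1 (`COc1cc(OC)c(OC)cc1/C=C/COC(=O)/C=C/c1ccc(OC)c(OC)c1`) gives 418 umol/kg there, compound 2 (`COc1cc(OC)c(OC)cc1/C=C/COC(=O)/C=C/c1c(OC)ccc(OC)c1OC`) gives 476 umol/kg there and compound 3 (`COc1cc(OC)c(OC)cc1/C=C/COC(=O)/C=C/c1cc(OC)c(OC)c(OC)c1OC`) gives 327 umol/kg there. These numbers lie within the usual scatter of one another, so compound 1 stands level with both others and no ranking can be drawn among the three.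

Compound 4 (`COc1cc(OC)c(OC)cc1/C=C/COC(=O)/C=C/c1ccccc1C(F)(F)F`) has no number yet. It keeps the shared core of compound 1 and carries 2-(trifluoromethyl)phenyl in place of 3,4-dimethoxyphenyl on a double-bonded chain carbon bound to a double-bonded chain carbon. Among the measured compounds shown here, no step between measured compounds isolates a single place, and none of the measured compounds carries trifluoromethyl, so this change has no direct precedent.

For the measured compounds named here, the only guide is the narrow spread, with compound 2 at 476 umol/kg and compound 3 at 327 umol/kg within the scatter of compound 1 at 418 umol/kg in this assay so far. No shift beyond the scatter is expected in either direction. An expected step of a 1.1-fold lower number from compound 1 to compound 4 (0.04 log units; within the scatter) would stay within the scatter. Compound 4 is estimated at 380 umol/kg in this assay with an expected range from 180 umol/kg to 750 umol/kg on this read-out.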

Compound 4, dose for half-maximal effect: > 473 umol/kg
Compound 4 was reported as a limit; the forecaster's own chance of this, stated with the estimate: 5%; middle value at least 1.2-fold (0.09 log units) from the limit.
By their numbers in this assay, from the lowest: compounds 3, 1 and 2 (each within the scatter of the next).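

Compound 4 gives > 473 umol/kg in this assay, and this is a limit of the assay and not a number. Setting 2-(trifluoromethyl)phenyl in place of 3,4-dimethoxyphenyl on a double-bonded chain carbon bound to a double-bonded chain carbon gives the first step in the series that isolates a single place, an at least 1.1-fold higher number from compound 1 to compound 4 (0.05 log units; that floor lies within the scatter), so the floor of this step does not separate compound 4 from compound 1, and its true size stays unknown. The reading of this change therefore rests on one open-ended result, and the earlier compounds, all of which carry methoxy groups on this ring, offered no comparison of this kind: the limit of > 473 umol/kg in this assay, at which 1 of the 4 values shown sits.

The compounds shown do not tell whether the step follows from the loss of the two methoxy groups or from the entry of trifluoromethyl, and an unsubstituted phenyl at this place would separate the two. As far as these compounds go, how a phenyl carrying an amine or a carboxylic acid would read at the same place in this assay also stays open.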